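This account rests on a few compounds, and the source may have more. Where it says the series, first, only, none or still open, it means among the compounds named here.

Of the compounds shown here, three have been measured so far in a functional assay on HeLa cells (Homo sapiens) for cytotoxicity, read by sulforhodamine B assay, with a stated time of 48 h; a higher number here means a weaker inhibitor, a lower number a stronger inhibitor. Compound 1 `CC(=O)OC[C@H]1O[C@@H](n2cc(CN3C(=O)/C(=C\c4ccccc4)c4ccccc43)nn2)[C@H](OC(C)=O)[C@@H](OC(C)=O)[C@@H]1OC(C)=O` gives 33300 nM. Compound 2 `CC(=O)OC[C@H]1O[C@@H](n2cc(CN3C(=O)/C(=C/c4ccccc4)c4ccccc43)nn2)[C@H](OC(C)=O)[C@@H](OC(C)=O)[C@@H]1OC(C)=O` gives 37100 nM. These two have the same atoms and bonds and differ only in the drawn configuration of a double bond, and the step of a 1.1-fold higher number from compound 1 to compound 2 (0.05 log units; within the scatter) is within the scatter. Compound 3 `CC(=O)OC[C@H]1O[C@@H](n2cc(CN3C(=O)/C(=C\c4cccs4)c4ccccc43)nn2)[C@H](OC(C)=O)[C@@H](OC(C)=O)[C@@H]1OC(C)=O` gives only a limit of the assay, > 100000 nM. Among the two plain numbers, compound 2 has the higher one, with compound 1 nearest and within the scatter of it.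

Compound 4 `CCC/C=C1/C(=O)N(Cc2cn([C@@H]3O[C@H](COC(C)=O)[C@@H](OC(C)=O)[C@H](OC(C)=O)[C@H]3OC(C)=O)nn2)c2ccccc21` has not yet been measured. Relative to compound 2 it differs in one place: propyl in place of phenyl on a double-bonded chain carbon bound to a double-bonded ring carbon. The step that bears most on this change sits at the same place, an at least 3.0-fold higher number from compound 1 to compound 3 (0.47 log units; beyond the scatter), where another group replaced phenyl and the number rose at least modestly. The configuration step a 1.1-fold higher number from compound 1 to compound 2 (0.05 log units; within the scatter) shows that the drawn geometry alone changes little. A rise beyond the scatter is therefore expected for compound 4, roughly a 2.0-fold higher number from compound 2 to compound 4 (0.31 log units; beyond the scatter). Compound 4 is estimated to give about 75000 nM, somewhere between 30000 nM and 200000 nM.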

Compound 4, half-maximal inhibitory concentration: > 100000 nM
Compound 4 gave a limit, no number; the forecaster's own chance of this, stated with the estimate: 35%; at least 1.3-fold (0.12 log units) between middle value and limit.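

Replacing phenyl gives an at least 2.6-fold higher number from compound 2 to compound 4 (0.43 log units; beyond the scatter) in this assay, so a group with no ring at this place does not match the phenyl of compound 2. Earlier, the only replacement at this place was thiophen-2-yl, which still has a ring; now propyl also ends at a limit, and among the groups shown only phenyl, in compound 1 and compound 2, gives a plain number. The size of this step cannot be read, and compound 3 and compound 4 cannot be ranked against each other, because each gives only a limit: the limit of > 100000 nM in this assay, at which 2 of the 4 values shown sit.

Going by these compounds, whether the ring itself matters or something else that separates phenyl from propyl remains open. A cyclohexyl group or a longer chain on the double-bonded chain carbon could help separate these possibilities.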